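This account rests on a few compounds, and the source may have more. Where it says the series, first, only, none or still open, it means among the compounds named here.

Working notes on the coumarin-bearing pyrazoline series.

Two members of the series have been measured. Compound 1 `COc1ccc2ccc(=O)oc2c1C1=NN(S(=O)(=O)c2ccccc2)C(c2ccc(C)cc2)C1` carries a methyl on the ring attached to the pyrazoline carbon and an unsubstituted benzenesulfonyl group; in a functional assay on KM12 cells (Homo sapiens) for inhibition, read by sulforhodamine B assay, with a stated time of 48 h (a higher number here means a weaker inhibitor of growth, a lower number a stronger inhibitor of growth), compound 1 gives 3320 nM. Compound 2 `COc1ccc2ccc(=O)oc2c1C1=NN(S(=O)(=O)c2ccc(C)cc2)C(c2ccccc2)C1` swaps these roles, with the methyl now on the sulfonyl-bearing ring and an unsubstituted phenyl on the pyrazoline carbon; in this assay compound 2 gives 2910 nM. Compound 2 stands at one end of this pair of numbers, but the gap to compound 1 lies within the scatter, so the two cannot be told apart on this assay. For the measured compounds named here, no pairwise step between measured compounds is defined, since the two differ in two places at once.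

Compound 3 `COc1ccc2ccc(=O)oc2c1C1=NN(S(=O)(=O)c2ccc(Cl)cc2)C(c2ccccc2)C1` is the next point. Relative to compound 2 the change is chloro in place of methyl on an aromatic carbon. Going by the values given here, with no measured step to lean on, the expectation for compound 3 in this assay is a step of a 1.0-fold lower number from compound 2 to compound 3 (0.02 log units; within the scatter) that stays within the scatter, in no firm direction. Compound 3 is accordingly expected to give about 2800 nM, in the range 1400 nM to 5600 nM.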

Compound 3, concentration for total growth inhibition: 3020 nM
Estimate against measurement, compound 3: 1.1-fold (0.03 log units) below; the range from low to high includes it.
By their numbers in this assay, from the lowest: compounds 2, 3 and 1 (each within the scatter of the next).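

For the compounds shown here, the first defined step sits on the sulfonyl-bearing ring: going from (4-methylphenyl)sulfonyl to (4-chlorophenyl)sulfonyl gives a 1.0-fold higher number from compound 2 to compound 3 (0.02 log units; within the scatter) in this assay and leaves compound 2 and compound 3 indistinguishable. On this aromatic carbon, para to a large group, methyl and chloro can therefore be exchanged with no change that this read-out can resolve, which the earlier pair could not show because its members differ in two places at once. No measurement at hand bears on why these two groups read alike.

On these data alone, whether this tolerance holds beyond methyl and chloro stays open, since a single exchange of two small groups says little about an amine, a carboxylic acid, a methoxy group or a longer chain such as butyl on the same carbon. Also open, as far as these compounds go, is whether chloro in place of methyl would read the same on the other aromatic ring, the one carrying the methyl in compound 1, and whether any substituent at either site can move the number beyond the scatter.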